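Methyl to chloro ortho to the carboxy group: notes

The source may hold more compounds than are shown below. What is called first, only, known or untested is meant among the compounds shown, and "the series" means these compounds.

Measured so far:
- compound 1, `COC(=O)c1ccc(OCCCCOc2ccc(C(=O)CC(C)C)c(O)c2C)cc1`; in an assay on HEK293 cells for positive allosteric modulation of metabotropic glutamate receptor 3 (Rattus norvegicus), read by thallium flux, with a stated time of 2.5 min (a lower number here means that less compound is needed, a higher number that more compound is needed for the effect), compound 1 has no reported result, "not determined" (no result reported).
- compound 2, `Cc1cc(OCCCCOc2ccc(C(=O)CC(C)C)c(O)c2C)ccc1C(=O)O`; in this assay compound 2 gives 3910 nM.

Within the data shown here, compound 2 therefore carries the only number; compound 1 stands beside it without a single value, so there is no measured step between compounds that differ in one place, and nothing in the data tells how a change on the carboxy-bearing part of the shared core shifts the read-out.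

Compound 3, `Cc1c(OCCCCOc2ccc(C(=O)O)c(Cl)c2)ccc(C(=O)CC(C)C)c1O`, differs from compound 2 by chloro in place of methyl on an aromatic carbon. Among the measured compounds shown here, with no measured step to lean on, the expectation is a step of no particular direction and of a size not beyond the usual scatter of repeated measurements. The step expected is a 1.1-fold lower number from compound 2 to compound 3 (0.05 log units; within the scatter), which is taken as within that scatter. Compound 3 is expected to give 3500 nM in this assay, with a range from 1200 nM to 10000 nM. Compound 2 with 3910 nM lies well inside the measured range, and a result for compound 3 inside that range is expected as well.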

Compound 3, half-maximal effective concentration: 2050 nM
Compound 3: the middle estimate sits 1.7-fold (0.23 log units) above what was measured; low and high end bracket the measured number.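

In this assay, the series now has its first measured step: chloro in place of methyl on an aromatic carbon, ortho to a carboxy group, gives a 1.9-fold lower number from compound 2 to compound 3 (0.28 log units; within the scatter) and so does not separate the two groups at this position. The change from 4-carboxy-3-methylphenyl to 4-carboxy-3-chlorophenyl therefore leaves the read-out within what repeated measurements would show, and this position accepts either group with no difference that can be read from this pair. Nothing measured on these compounds speaks to why the two groups read alike, and a single pair gives no ground for a trend at this position.

The compounds shown leave open whether a fluoro, a methoxy, an amine or a phenyl at this same position would also stay within the scatter, or whether one of them would give a step beyond it. They also leave open whether the same exchange of methyl for chloro reads alike with a tetrazole in place of the carboxylic acid, or with a longer chain joining the two aromatic parts.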